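Series notes: amide-to-aryl change on the carbonyl carbon

The source may hold more compounds than are shown below. What is called first, only, known or untested is meant among the compounds shown, and "the series" means these compounds.

Compound 1 `COc1cc(-c2nn(-c3cccc(NC(=O)c4cccc(C(F)(F)F)c4)c3)cc2-c2ccncc2)ccc1Cl` gives 895 nM in a functional assay on SF-539 cells (Homo sapiens) for inhibition, read by sulforhodamine B assay, with a stated time of 48 h; on this read-out lower numbers stand for stronger inhibition of growth and higher numbers for weaker inhibition of growth. Compound 2 `COc1cc(-c2nn(-c3cccc(NC(=O)Nc4cccc(C(F)(F)F)c4)c3)cc2-c2ccncc2)ccc1Cl` gives 890 nM in this assay, and the step of a 1.0-fold lower number from compound 1 to compound 2 (0.00 log units; within the scatter) puts the two within the scatter of each other, so compound 2 stands level with compound 1 on the two numbers shown. Compound 3 `COc1cc(-c2nn(-c3cccc(NC(=O)c4ccc(Cl)c(C(F)(F)F)c4)c3)cc2-c2ccncc2)ccc1Cl` differs from compound 2 by 4-chloro-3-(trifluoromethyl)phenyl in place of (3-(trifluoromethyl)phenyl)amino on a carbonyl carbon. Among the compounds with values here, the only measured step touching this carbonyl carbon, a 1.0-fold lower number from compound 1 to compound 2 (0.00 log units; within the scatter), changed nothing beyond the scatter; no step tests the added chlorine. A step of a 1.0-fold lower number from compound 2 to compound 3 (0.02 log units; within the scatter) is therefore expected, none beyond the scatter. Compound 3 is estimated at 850 nM, range 300 nM to 2500 nM.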

Compound 3, concentration for 50% growth inhibition: 4130 nM
Estimate against measurement, compound 3: 4.9-fold (0.69 log units) below; the measured number lies above the stated range.
By their numbers in this assay, from the lowest: compounds 2 and 1 (each within the scatter of the next); then compound 3.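

On the aromatic ring carried by the carbonyl carbon, chloro in place of hydrogen on an aromatic carbon gives a 4.6-fold higher number from compound 1 to compound 3 (0.66 log units; beyond the scatter) in this assay, so this ring responds to a change where the earlier carbonyl-carbon step did not. The step of a 4.6-fold higher number from compound 2 to compound 3 (0.67 log units; beyond the scatter) is of similar size, but it combines the added chlorine with the loss of the amino link and cannot separate the two changes. Nothing available explains why the added chlorine raises the number.

As far as these compounds go, whether the same chlorine has a similar effect on the (3-(trifluoromethyl)phenyl)amino group of compound 2 remains open. Also open, from the compounds shown here alone, is whether fluoro, methoxy or an amine in place of that chlorine would give a similar number.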